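This account rests on a few compounds, and the source may have more. Where it says the series, first, only, none or still open, it means among the compounds named here.

Measured so far in an assay on isolated protein for inhibition of ubiquitin carboxyl-terminal hydrolase 7 (Homo sapiens), with stated times of 30 min and 2 h; a lower number here means a stronger inhibitor, a higher number a weaker inhibitor:
compound 1 `Cn1nc2c(=O)n(CC3(O)CCN(Cc4ccc(-c5ccncc5)cc4Cl)CC3)cnc2c1-c1ccc(CN)cc1` gives 257 nM
compound 2 `Cn1nc2c(=O)n(CC3(O)CCN(Cc4ccc(C5CCCO5)cc4Cl)CC3)cnc2c1-c1ccc(CN)cc1` gives 3820 nM

Among the compounds with values here, compound 2 stands at the higher of the two numbers; the gap to the only other value is a 15-fold higher number from compound 1 to compound 2 (1.17 log units; beyond the scatter), beyond the scatter. Compound 3 `Cn1nc2c(=O)n(CC3(O)CCN(Cc4ccc(-c5ccc[nH]5)cc4Cl)CC3)cnc2c1-c1ccc(CN)cc1` is not yet measured; its change from compound 2 is 1H-pyrrol-2-yl in place of oxolan-2-yl on an aromatic carbon. Within the data shown here, the one step that bears on it is a 15-fold higher number from compound 1 to compound 2 (1.17 log units; beyond the scatter), which traded a six-membered aromatic ring for oxolan-2-yl at the same carbon. Compound 3 restores a five-membered aromatic ring there, so a step down is expected, likely partial: a 4.2-fold lower number from compound 2 to compound 3 (0.63 log units; beyond the scatter). Compound 3 is estimated at 900 nM, range 250 nM to 3000 nM.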

Compound 3, half-maximal inhibitory concentration: 193 nM
Beside the measured number, compound 3's estimate is 4.7-fold (0.67 log units) above it; measured number below the stated range.
By their numbers in this assay, from the lowest: compounds 3 and 1 (each within the scatter of the next); then compound 2.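

At this carbon, para to a large group, 1H-pyrrol-2-yl in place of oxolan-2-yl gives a 20-fold lower number from compound 2 to compound 3 (1.30 log units; beyond the scatter) in this assay, so a five-membered ring as such does not carry the loss seen with oxolan-2-yl. With a 1.3-fold lower number from compound 1 to compound 3 (0.12 log units; within the scatter) as the step from pyridin-4-yl, a six-membered aromatic ring is not required here. No measured evidence accounts for either step.

The oxolan-2-yl to 1H-pyrrol-2-yl change alters aromaticity and hydrogen-bond donor count together, and these remain unseparated. Furan-2-yl or phenyl at this carbon would bear on that.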